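The source may hold more compounds than are shown below. What is called first, only, known or untested is meant among the compounds shown, and "the series" means these compounds.

Three measured compounds share one core, and a fourth remains to be measured. In a physicochemical assay for solubility, at pH 7.4 (on this read-out higher numbers stand for higher solubility and lower numbers for lower solubility), compound 1 `Cc1cc(Cl)c(-c2cn(C)cn2)cc1NC(=O)c1ccc(OCc2ccccn2)cc1` gives 20000 nM. In this assay compound 2 `Cc1cc(C)c(-c2cn(C)cn2)cc1NC(=O)c1ccc(OCc2ccccn2)cc1` gives 8000 nM, and compound 3 `Cc1ccc(-c2ncc[nH]2)c(C)c1NC(=O)c1ccc(OCc2ccccn2)cc1` gives 69000 nM. Compound 2 therefore stands lowest of the three numbers: compound 1 is its nearest neighbour, while compound 3 lies furthest from it. Among the compounds with values here, the only single step between measured compounds is a 2.5-fold lower number from compound 1 to compound 2 (0.40 log units; beyond the scatter), which concerns a different part of the molecule and does not bear directly on the change now considered.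

Compound 4 `Cc1cc(C)c(-c2c[nH]nc2C)cc1NC(=O)c1ccc(OCc2ccccn2)cc1` differs from compound 2 in one place: 3-methyl-1H-pyrazol-4-yl in place of 1-methyl-1H-imidazol-4-yl on an aromatic carbon. Within the data shown here, no measured pair isolates this exchange. Compound 3, which carries a different five-membered ring with a ring hydrogen, shows the highest number of the three, but it also differs from compound 2 in the placement of its methyl groups, so its value is only a hint, not a step. Given that compound 3 shows 69000 nM, a modest rise is expected for compound 4, with an estimated 2.0-fold higher number from compound 2 to compound 4 (0.30 log units; within the scatter). The estimated value of compound 4 is 16000 nM, within a range of 5000 nM to 50000 nM.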

Compound 4, solubility: 33000 nM
The estimate for compound 4 lay 2.1-fold (0.31 log units) below the measured number; the range from low to high includes it.
By their numbers in this assay, from the lowest: compound 2; then compounds 1 and 4 (each within the scatter of the next); then compound 3.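

In this assay, the exchange of 1-methyl-1H-imidazol-4-yl for 3-methyl-1H-pyrazol-4-yl gives a 4.1-fold higher number from compound 2 to compound 4 (0.62 log units; beyond the scatter), the first step read at this position, an aromatic carbon ortho to a methyl group and para to a methyl group. The earlier step from chloro to methyl lay in another place, so only now is it seen that the number moves beyond the scatter when one five-membered aromatic ring with 2 hetero atoms replaces another of equal size, with 1 hydrogen-bond donor and 1 hydrogen-bond acceptor entering where 0 donors and 2 acceptors leave. No available evidence accounts for this rise.

The compounds shown leave open how much of the step goes with the nitrogen-bound hydrogen and how much with the place of the methyl group, a question that 1H-pyrazol-4-yl and 1,3-dimethyl-1H-pyrazol-4-yl at the same position would help to separate. They also leave open whether 3-methyl-1H-pyrazol-4-yl gives a step of similar size on the core of compound 1, which carries the chloro group.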